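The source may report more compounds than this note shows. Statements on the series, on what has been measured and on what is new or still open speak of the compounds shown alone.

Measured in a functional assay on DU-145 cells (Homo sapiens) for cytotoxicity, read by MTT assay; a higher number here means a weaker inhibitor, a lower number a stronger inhibitor:
compound 1 `CC[C@@](C)(O)CC(=O)O[C@H](CC=C(C)C)C1=CC(=O)c2c(O)ccc(O)c2C1=O`, for which compound 1 gives 12700 nM;
compound 2 `COC(C)CO[C@H](CC=C(C)C)C1=CC(=O)c2c(O)ccc(O)c2C1=O`, for which compound 2 gives 16600 nM;
compound 3 `CCCCC(C)(O)CC(=O)O[C@H](CC=C(C)C)C1=CC(=O)c2c(O)ccc(O)c2C1=O`, for which compound 3 gives 76500 nM.

Of these three numbers, compound 1 has the lowest. Its nearest neighbour is compound 2, and that step, a 1.3-fold higher number from compound 1 to compound 2 (0.12 log units; within the scatter), separates nothing. Its furthest neighbour is compound 3, where the step reads a 6.0-fold higher number from compound 1 to compound 3 (0.78 log units; beyond the scatter). Between the other two, a 4.6-fold higher number from compound 2 to compound 3 (0.66 log units; beyond the scatter).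

Compound 4 `CC(C)=CC[C@@H](OC(=O)C1CCCOC1)C1=CC(=O)c2c(O)ccc(O)c2C1=O` is the compound still to be measured. It differs from compound 1 in one place: oxan-3-yl in place of 2-hydroxy-2-methylbutyl on a carbonyl carbon.

Among the measured compounds shown here, two measured steps bear on this change. The step from compound 1 to compound 3 altered the same group, lengthening the hydroxyl-bearing chain, and raised the number modestly. The step from compound 1 to compound 2 removed both the carbonyl and the hydroxyl at that oxygen and stayed within the scatter. Neither step brought in a ring, so the exchange of the hydroxyl-bearing chain for the oxan-3-yl ring, equal in heavy-atom count, is without a direct precedent. On these two steps, a small shift toward a higher number, or none beyond the scatter, is expected in this assay.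

Compound 4 is therefore estimated at 18000 nM in this assay, with a likely range of 7000 nM to 50000 nM. The expected step is a 1.4-fold higher number from compound 1 to compound 4 (0.15 log units; within the scatter).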

Compound 4, half-maximal inhibitory concentration: 29700 nM
Estimate against measurement, compound 4: 1.7-fold (0.22 log units) below; measured number inside the range.
By their numbers in this assay, from the lowest: compounds 1, 2 and 4 (each within the scatter of the next, the first and the last beyond it); then compound 3.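

In this assay, the exchange on the carbonyl carbon of 2-hydroxy-2-methylbutyl for oxan-3-yl, both of 6 heavy atoms, gives a step beyond the scatter (a 2.3-fold higher number from compound 1 to compound 4 (0.37 log units; beyond the scatter)), so closing the chain into a ring and going from 1 hydrogen-bond donor to 0 is not a silent change at this position, though the step is modest. Against the longer 2-hydroxy-2-methylhexyl, the same ring gives a step of similar size in the opposite direction (a 2.6-fold lower number from compound 3 to compound 4 (0.41 log units; beyond the scatter)), which places compound 4 within the span of the two hydroxyl-bearing chains, while the step against 2-methoxypropyl on the oxygen (a 1.8-fold higher number from compound 2 to compound 4 (0.25 log units; within the scatter)) separates nothing. Nothing in the material shown bears on why these steps take the size they do.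

The compounds shown leave open whether the ring or its oxygen accounts for the step, a question that a cyclohexyl ring or a piperidine ring, with an amine nitrogen in that place, on the same carbonyl carbon would address. They also leave open how oxan-4-yl, which attaches the same ring through a different carbon, would read in this assay.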